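Swapping a Hydroxyethyl Ester for an Acid-Bearing Amide

The compounds below may be only part of what the source reports. "The series", "measured", "known", "first", "only" and "open" are said of these compounds alone.

Measured so far:
compound 1 `CCn1cc(C(CC)(CC)c2ccc(C#CC(O)(CC)CC)c(C)c2)cc1C(=O)NCCCN(C)C` — 142 nM
compound 2 `CCn1cc(C(CC)(CC)c2ccc(C#CC(O)(CC)CC)c(C)c2)cc1C(=O)OCCO` — 12.6 nM

Within the data shown here, in an assay on cells for agonist activity at vitamin D3 receptor (Homo sapiens), read by microscopy (a lower number here means that less compound is needed, a higher number that more compound is needed for the effect), compound 2 gives the lowest of the two numbers; the single measured step, an 11-fold lower number from compound 1 to compound 2 (1.05 log units; beyond the scatter), separates it from compound 1. Compound 3 `CCn1cc(C(CC)(CC)c2ccc(C#CC(O)(CC)CC)c(C)c2)cc1C(=O)NCCC(=O)O` differs from compound 2 by (2-carboxyethyl)amino in place of 2-hydroxyethoxy on a carbonyl carbon. Among the measured compounds shown here, the measured step replaced an amide by an ester and lowered the number sharply; compound 3 returns to an amide, yet carries a carboxylic acid rather than an amine, so no measured step matches it closely. For compound 3 a moderate rise is expected, a 3.2-fold higher number from compound 2 to compound 3 (0.50 log units; beyond the scatter). The estimate for compound 3 is 40 nM, ranging from 10 nM to 160 nM.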

Compound 3, half-maximal effective concentration: > 50 nM
Compound 3 was reported as a limit; the forecaster's own chance of this, stated with the estimate: 5%; middle value at least 1.2-fold (0.09 log units) away from the limit.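

In this assay, the low number of compound 2 does not carry over when (2-carboxyethyl)amino takes the place of 2-hydroxyethoxy on this carbonyl carbon, with an at least 3.9-fold higher number from compound 2 to compound 3 (0.59 log units; beyond the scatter) as the step. Compound 3 is reported only as a limit, not as a number: the limit of > 50 nM in this assay, at which 1 of the 3 values shown sits. The step between compound 1 and compound 3 cannot be read, so the amine-bearing and acid-bearing amides cannot be ranked.

Still open, on these data alone, is whether the ester link or the end group matters more in compound 2. A 2-hydroxyethyl amide or a plain ethyl ester on this carbonyl carbon would help separate the two.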